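This account rests on a few compounds, and the source may have more. Where it says the series, first, only, none or still open, it means among the compounds named here.

Compound 3 `Cc1ccc(N2C(=O)NC3(CSC4=C3C(=O)c3ncccc3C4=O)C2=O)cc1` is the compound from which this step is taken. Among the measured compounds shown here, in a functional assay on CCRF-SB cells (Homo sapiens) for antiproliferative activity, read by MTT assay, with a stated time of 96 h (on this read-out higher numbers stand for weaker inhibition and lower numbers for stronger inhibition), compound 3 gives 20 nM, the highest of the three numbers measured so far. Compound 2 `COc1ccc(N2C(=O)NC3(CSC4=C3C(=O)c3ncccc3C4=O)C2=O)cc1` gives 10 nM in this assay, and the step of a 2.0-fold higher number from compound 2 to compound 3 (0.30 log units; within the scatter) lies within the scatter, so the two cannot be placed in order. Compound 1 `CCCc1ccc(N2C(=O)NC3(CSC4=C3C(=O)c3ncccc3C4=O)C2=O)cc1` gives 2 nM in this assay, and the step of a 10-fold higher number from compound 1 to compound 3 (1.00 log units; beyond the scatter) lies beyond the scatter, as does a 5.0-fold higher number from compound 1 to compound 2 (0.70 log units; beyond the scatter).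

Compound 4 `CC(C)(C)c1ccc(N2C(=O)NC3(CSC4=C3C(=O)c3ncccc3C4=O)C2=O)cc1` is not yet measured. Its change from compound 3 is tert-butyl in place of methyl on an aromatic carbon. The measured step that bears on it most directly is a 10-fold higher number from compound 1 to compound 3 (1.00 log units; beyond the scatter), where a propyl in place of a methyl on the same aromatic carbon was met by the lowest number of the three. The methoxy compound also sits within the scatter of compound 3, so the series says little against added carbon at that position. On that basis compound 4 is expected to show a lower number, a step of about a 4.0-fold lower number from compound 3 to compound 4 (0.60 log units; beyond the scatter). The estimate for compound 4 in this assay is 5 nM, with a range from 1.5 nM to 15 nM.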

Compound 4, half-maximal inhibitory concentration: 200 nM
Estimate against measurement, compound 4: 40-fold (1.60 log units) below; the whole stated range lies below it.
By their numbers in this assay, from the lowest: compound 1; then compounds 2 and 3 (each within the scatter of the next); then compound 4.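

In this assay, the result shows that adding carbon at this position does not by itself lower the number, for the change from methyl to tert-butyl raises it (a 10-fold higher number from compound 3 to compound 4 (1.00 log units; beyond the scatter)), whereas compound 1, with propyl on the same aromatic carbon, holds the lowest number of the series. The identity of the alkyl group therefore decides the outcome, not merely its presence: the step between the two larger groups is the widest in the series (a 100-fold higher number from compound 1 to compound 4 (2.00 log units; beyond the scatter)), and tert-butyl also stands well clear of methoxy (a 20-fold higher number from compound 2 to compound 4 (1.30 log units; beyond the scatter)), leaving compound 4 the weakest of the four, with all its steps beyond the scatter. Nothing available explains why these two groups part so sharply.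

The compounds shown leave open whether the rise follows from branching or from the size of the group, a question that an isopropyl group or a straight butyl chain on the same aromatic carbon would address. They also leave open how far a longer chain would hold the low number of compound 1, and how an amine or a carboxylic acid would fare at this position.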